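This account rests on a few compounds, and the source may have more. Where it says the series, first, only, none or still open, it means among the compounds named here.

Of the compounds shown here, three built on one shared core have been measured in an assay for binding affinity to dual specificity mitogen-activated protein kinase kinase 4 (Homo sapiens), read by KINOMEscan, tested at 100 nM; a lower number here means a stronger effect, a higher number a weaker effect of the compound at the concentration tested. Compound 1 `CCCS(=O)(=O)Nc1ccc(F)c(C(=O)c2n[nH]c3ncc(-c4cccc(F)c4)cc23)c1F` gives 8.2%, compound 2 `CCCS(=O)(=O)Nc1ccc(F)c(C(=O)c2n[nH]c3ncc(-c4ccccc4O)cc23)c1F` gives 9%, and compound 3 `CCCS(=O)(=O)Nc1ccc(F)c(C(=O)c2n[nH]c3ncc(-c4ccc(N(C)C)cc4)cc23)c1F` gives 2.5%. Compound 3 thus stands at the lowest of the three numbers, but the gaps to its neighbours are a number 5.7 percentage points lower from compound 1 to compound 3 (within the scatter) and a number 6.5 percentage points lower from compound 2 to compound 3 (within the scatter), so the three compounds are not set apart from one another; the remaining pair shows a number 0.8 percentage points higher from compound 1 to compound 2 (within the scatter).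

Compound 4 `CCCS(=O)(=O)Nc1ccc(F)c(C(=O)c2n[nH]c3ncc(-c4ccc(OC)cc4Cl)cc23)c1F` has not yet been measured in this assay. It differs from compound 3 in one place: 2-chloro-4-methoxyphenyl in place of 4-(dimethylamino)phenyl on an aromatic carbon. Among the measured compounds shown here, the steps that bear on this exchange are the two already made at the same aromatic carbon, from compound 1 and from compound 2 to compound 3, and both of them were small. On that basis the step of a number 3.5 percentage points higher from compound 3 to compound 4 (within the scatter) is expected to be of the same order, not beyond the scatter. Compound 4 is therefore estimated to give 6% in this assay, with a range from 1% to 20%.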

Compound 4, a percentage reported as activity, at one concentration (the size of the read-out at that concentration, not a potency): 5.3%
Beside the measured number, compound 4's estimate is 0.7 percentage points above it; low and high end bracket the measured number.
By their numbers in this assay, from the lowest: compounds 3, 4, 1 and 2 (each within the scatter of the next).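

In this assay, the 2-chloro-4-methoxyphenyl group, which carries both a chlorine and a methoxy group on its ring, leaves the reading as close to the others as the singly substituted phenyl groups do: a number 2.8 percentage points higher from compound 3 to compound 4 (within the scatter), a number 3.7 percentage points lower from compound 2 to compound 4 (within the scatter) and a number 2.9 percentage points lower from compound 1 to compound 4 (within the scatter). All four phenyl groups at this aromatic carbon therefore remain unseparated, and this now holds for a ring bearing two substituents as well as for rings bearing one. No evidence is available that bears on why this exchange leaves the reading within the scatter.

On these data alone, it remains open whether a group other than a substituted phenyl, such as a morpholine, a carboxylic acid or a plain hydrogen, would move the reading at this carbon. A reading at a single concentration also leaves open whether these four compounds differ in potency.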